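Trimming the chain on the ring carbon: compound 3

The source may hold more compounds than are shown below. What is called first, only, known or untested is meant among the compounds shown, and "the series" means these compounds.

Compound 1 `CC[C@@H]1c2cc(Cl)ccc2C(=O)N1c1cncc2c1CCC[C@H]2NC(C)=O`: 7 nM
Compound 2 `CC(=O)N[C@@H]1CCCc2c1cncc2N1C(=O)c2ccc(Cl)cc2[C@H]1C`: 130 nM

Of the compounds shown here, two have been measured in an assay on cells for inhibition of cytochrome P450 11B2, mitochondrial (Homo sapiens), read by HTRF; a higher number here means a weaker inhibitor, a lower number a stronger inhibitor. Compound 2 stands with the highest of the two numbers; its nearest neighbour is compound 1, and the step of a 19-fold higher number from compound 1 to compound 2 (1.27 log units; beyond the scatter) is large. That step puts hydrogen in place of methyl on a saturated chain carbon bound to a saturated ring carbon, so that compound 2 keeps only a methyl on that ring carbon.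

Compound 3 `CC(=O)N[C@@H]1CCCc2c1cncc2N1Cc2cc(Cl)ccc2C1=O` has not yet been measured. It differs from compound 2 by hydrogen in place of methyl on a saturated ring carbon, that is, the last carbon on that ring carbon is taken away as well. Going by the values given here, only one measured step bears on this change, the one from compound 1 to compound 2, and it was large and in the weakening direction. The shorter chain is therefore expected to cost potency again, though the size of a second cut cannot be read from one step alone. Compound 3 is expected to give about 1000 nM, with a range of 300 nM to 4000 nM, a step of a 7.7-fold higher number from compound 2 to compound 3 (0.89 log units; beyond the scatter).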

Compound 3, half-maximal inhibitory concentration: 44 nM
Compound 3: middle estimate off by 23-fold (1.36 log units), on the high side, outside the stated range (below it).
By their numbers in this assay, from the lowest: compound 1; then compound 3; then compound 2.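

In this assay, taking away the last carbon on this saturated ring carbon, next to the ring nitrogen, does not extend the loss seen on going from ethyl to methyl: removing the methyl gives a 3.0-fold lower number from compound 2 to compound 3 (0.47 log units; beyond the scatter) and so reverses part of that loss. Ethyl still holds an advantage over hydrogen at this position, as a 6.3-fold higher number from compound 1 to compound 3 (0.80 log units; beyond the scatter) shows, which places hydrogen between the other two groups and leaves methyl with the highest number of the series. The numbers therefore do not follow chain length in a single direction across hydrogen, methyl and ethyl, with compound 2 going against any steady trend, and nothing available accounts for this turn.

Going by these compounds, whether a propyl group or a longer chain would bring a further gain beyond ethyl, or whether ethyl is already near the best length, remains open. Also open, on these data alone, is how a cyclopropyl ring or a hydroxymethyl group on this carbon would compare with the ethyl of compound 1 and the hydrogen of compound 3.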